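This account rests on a few compounds, and the source may have more. Where it says the series, first, only, none or still open, it means among the compounds named here.

Compound 1 `N=C(NCc1ccc(O)cc1)[C@@H]1CCC(=O)N1Cc1ccccc1[N+](=O)[O-]` serves as the reference point of this small set. In a functional assay on SH-SY5Y cells (Homo sapiens) for cytotoxicity, read by MTT assay, with stated times of 8 h, 30 min and 12 h, tested at 5 uM (a higher number here means a stronger effect of the compound at the concentration tested, a lower number a weaker effect), compound 1 gives 30.4%. Compound 2 `COc1ccc(CNC(=N)[C@@H]2CCC(=O)N2Cc2ccccc2[N+](=O)[O-])cc1` carries a single change relative to compound 1, namely (methyl in place of hydrogen on an oxygen on an aromatic ring), and in this assay compound 2 gives 25.4%; the step between them is a number 5 percentage points lower from compound 1 to compound 2 (within the scatter). Compound 3 `Cc1ccc(CN2C(=O)CC[C@H]2C(=N)NCc2ccc(O)cc2)cc1` differs from compound 1 in its core, (4-methylphenyl in place of 2-nitrophenyl on a saturated chain carbon bound to an amide-type nitrogen in a ring), and in this assay compound 3 gives 23.8%; that step is a number 6.6 percentage points lower from compound 1 to compound 3 (within the scatter). Compound 4 `COc1ccc(CNC(=N)[C@@H]2CCC(=O)N2Cc2ccc(C)cc2)cc1` has not yet been measured. It differs from compound 3 by methyl in place of hydrogen on an oxygen on an aromatic ring, which is the same change, at the same place, that separates compound 2 from compound 1. Because the earlier step of a number 5 percentage points lower from compound 1 to compound 2 (within the scatter) lay within the scatter, a step of about the same size is expected for compound 4, a number 4.8 percentage points lower from compound 3 to compound 4 (within the scatter). Compound 4 is therefore estimated at 19% in this assay, with the expected range running from 10% to 29%.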

Compound 4, a percentage reported as activity, at one concentration (the size of the read-out at that concentration, not a potency): 29.5%
Beside the measured number, compound 4's estimate is 10.5 percentage points below it; the measured number lies above the stated range.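

In this assay, methyl in place of hydrogen on the oxygen of the aromatic ring gives a number 5.7 percentage points higher from compound 3 to compound 4 (within the scatter), and beside the same change on the core of compound 1 the two steps do not differ beyond the scatter: the same change on two cores in this assay, a number 5 percentage points lower (within the scatter) from compound 1 to compound 2 and a number 5.7 percentage points higher (within the scatter) from compound 3 to compound 4, 10.7 percentage points apart, within the scatter of two such steps. The other change, 4-methylphenyl in place of 2-nitrophenyl, gives a number 4.1 percentage points higher from compound 2 to compound 4 (within the scatter), and it too reads alike in both settings: the same change on two cores in this assay, a number 6.6 percentage points lower (within the scatter) from compound 1 to compound 3 and a number 4.1 percentage points higher (within the scatter) from compound 2 to compound 4, 10.7 percentage points apart, within the scatter of two such steps. Hydroxy to methoxy thus carries between these two cores without a detectable difference, but every step lies within the scatter, so this shows neither that the change has a real effect on either core nor that such an effect would be shared.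

The compounds shown leave open whether a longer chain on that oxygen, or an amine or a carboxylic acid in place of the hydroxy, would give a step beyond the scatter. They also leave open how the change behaves on any core other than these two.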